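The compounds below may be only part of what the source reports. "The series", "measured", "known", "first", "only" and "open" are said of these compounds alone.

Measured so far in a functional assay on RPMI-8226 cells (Homo sapiens) for inhibition; a higher number here means a weaker inhibitor, a lower number a stronger inhibitor:
compound 1 `N#CC1CN1C(=O)Nc1ccc(F)cc1` — 5000 nM
compound 2 `N#CC1CN1C(=O)Nc1ccc([N+](=O)[O-])cc1` — 9100 nM
compound 3 `N#CC1CN1C(=O)Nc1ccccc1` — 5300 nM

Compound 3 sits second highest of the three numbers, with compound 1 nearest and compound 2 furthest, and both of those gaps lie within the scatter. Compound 4 `N#CC1CN1C(=O)Nc1ccc(C(F)(F)F)cc1` is not yet measured; it differs from compound 3 by trifluoromethyl in place of hydrogen on an aromatic carbon, at the place described as para to a group of 8 heavy atoms. Going by the values given here, the steps that bear on this exchange at the same aromatic carbon are a 1.1-fold higher number from compound 1 to compound 3 (0.03 log units; within the scatter) and a 1.7-fold lower number from compound 2 to compound 3 (0.23 log units; within the scatter), both within the scatter. A step beyond the scatter in this assay is therefore not expected for compound 4, whose estimate is 5500 nM, range 2500 nM to 12000 nM, which means an expected 1.0-fold higher number from compound 3 to compound 4 (0.02 log units; within the scatter).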

Compound 4, half-maximal inhibitory concentration: 8200 nM
For compound 4 the middle estimate is 1.5-fold (0.17 log units) below the measured one, and the stated range covers the measured number.
By their numbers in this assay, from the lowest: compounds 1, 3, 4 and 2 (each within the scatter of the next).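

At the place para to a group of 8 heavy atoms, a group of 4 heavy atoms replaces hydrogen, and in this assay the steps remain small: a 1.5-fold higher number from compound 3 to compound 4 (0.19 log units; within the scatter), a 1.1-fold lower number from compound 2 to compound 4 (0.05 log units; within the scatter) and a 1.6-fold higher number from compound 1 to compound 4 (0.21 log units; within the scatter). Hydrogen, fluoro, nitro and trifluoromethyl at this aromatic carbon are therefore not separated by this assay. No supporting data bear on the reason for this.

Going by these compounds, whether an amine, a carboxylic acid or a longer chain at this carbon would give a step beyond the scatter remains open. Also open, on these data alone, is what exchanging the nitrile of the shared core would do.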